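The compounds below may be only part of what the source reports. "The series", "measured", "known", "first", "only" and "open" are said of these compounds alone.

Compound 2 `COc1cc(C)cc(-c2nn(CC#N)cc2-c2ccnc(-c3ccc(N(C)C)cc3)c2)c1` and compound 1 `Cc1cc(O)cc(-c2nn(CC#N)cc2-c2ccnc(-c3ccc(Oc4ccccc4)cc3)c2)c1` share a common core and differ at two outer groups. In a functional assay on BT-549 cells (Homo sapiens) for inhibition, read by sulforhodamine B assay, with a stated time of 48 h (a higher number here means a weaker inhibitor of growth, a lower number a stronger inhibitor of growth), compound 2 gives 1620 nM. In this assay compound 1 gives 2660 nM. Of the two numbers, that of compound 2 is the lower, but the two values lie within the usual scatter of each other, so nothing can be said about an order between them.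

The next compound, compound 3 `Cc1cc(O)cc(-c2nn(CC#N)cc2-c2ccnc(-c3ccc(N(C)C)cc3)c2)c1`, is reached from compound 2 by a single change: hydrogen in place of methyl on an oxygen on an aromatic ring. No pair of measured compounds shows this change on its own, so its size in this assay is not known from these data; the two measured values give no reason to expect a step beyond the scatter in either direction.

For compound 3 in this assay the expected value is 1600 nM, with a range from 700 nM to 3600 nM. The step this estimate implies, a 1.0-fold lower number from compound 2 to compound 3 (0.01 log units; within the scatter), is expected to stay within the scatter.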

Compound 3, concentration for 50% growth inhibition: 2770 nM
The estimate for compound 3 lay 1.7-fold (0.24 log units) below the measured number; the measured number falls inside the stated range.
By their numbers in this assay, from the lowest: compounds 2, 1 and 3 (each within the scatter of the next).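

Hydrogen in place of methyl on an oxygen on an aromatic ring comes to a 1.7-fold higher number from compound 2 to compound 3 (0.23 log units; within the scatter) in this assay, so methoxy and hydroxy on this ring cannot be told apart here when the dimethylamino group is held fixed. Among the compounds shown here, compound 3 also gives the first single-place comparison at the other end of the molecule: dimethylamino in place of phenoxy on an aromatic carbon amounts to a 1.0-fold higher number from compound 1 to compound 3 (0.02 log units; within the scatter) with the 3-hydroxy-5-methylphenyl group held fixed. Each of the two outer places has thus been changed once on its own, and neither change gives a step beyond the scatter in this assay, though each rests on a single pair. Nothing measured here bears on why these steps are so small.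

Whether the exchange of methoxy for hydroxy reads the same with phenoxy in place of dimethylamino remains open, since only the dimethylamino pair is shown. Also open, from the compounds shown here alone, is whether a larger change on that oxygen, such as an ethyl or a longer chain, or an amine or a carboxylic acid in place of the hydroxy group, would give a step beyond the scatter in this assay on these cells.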